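This account rests on a few compounds, and the source may have more. Where it says the series, first, only, none or still open, it means among the compounds named here.

In a functional assay on KB cells (Homo sapiens) for antiproliferative activity, read by sulforhodamine B assay, with a stated time of 3 days (a lower number here means a stronger inhibitor of growth, a higher number a weaker inhibitor of growth), compound 1 `O=C(c1cccc(Nc2ncc(F)c(Nc3ccc(F)cc3)n2)c1)N1CCCCC1` gives 14800 nM. Compound 2 `CN(C)c1ccc(C(=O)Nc2cccc(Nc3ncc(F)c(Nc4ccc(F)cc4)n3)c2)cc1` gives only a limit, > 10000 nM, and not a number. For compound 2 the record therefore stands at the limit of > 10000 nM in this assay, at which 1 of the 2 values shown sits. Compound 3 `O=C(Nc1cccc(Nc2ncc(F)c(Nc3ccc(F)cc3)n2)c1)c1ccccc1` differs from compound 2 at a single place, with hydrogen in place of dimethylamino on an aromatic carbon, para to a large group: hydrogen in place of dimethylamino on an aromatic carbon. For the measured compounds named here, no measured pair of compounds shows what this change does, so no shift beyond the usual scatter is expected in this assay, and no direction is favoured. The expected step, a step that the limit leaves unreadable from compound 2 to compound 3, is correspondingly small and uncertain. The expectation of weak growth inhibition rests on compound 1, with its value of 14800 nM. A limit is also a likely outcome for compound 3. Compound 3 is estimated at 12000 nM, with an expected range from 4000 nM to 30000 nM.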

Compound 3, concentration for 50% growth inhibition: > 10000 nM
Compound 3: a limit, no number; the forecaster's own chance of this, stated with the estimate: 45%; the middle value does not contradict the limit.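

In this assay compound 3 gives > 10000 nM, which is a limit and not a number, so neither its step from compound 2 nor its step from compound 1 can be read. The compounds shown leave open what replacing dimethylamino with hydrogen does to growth inhibition.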